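The compounds below may be only part of what the source reports. "The series", "measured", "known", "first", "only" and "open" are said of these compounds alone.

In a functional assay on PC-9 cells (Homo sapiens) for inhibition, read by MTT assay, with a stated time of 72 h (a lower number here means a stronger inhibitor, a higher number a weaker inhibitor), compound 1 `Cc1cc(Nc2cc(-c3ccccc3)[nH]n2)n2nc(SCCc3ccccc3)nc2n1` gives 4930 nM and compound 2 `Cc1cc(Nc2cc(-c3ccccc3)[nH]n2)n2nc(SCc3ccc(F)cc3)nc2n1` gives 8110 nM, a pair separated only by a 1.6-fold higher number from compound 1 to compound 2 (0.22 log units; within the scatter). Compound 3 `C#CCSc1nc2nc(C)cc(Nc3cc(-c4ccccc4)[nH]n3)n2n1` gives > 50000 nM, and this reading is a limit of the assay, not a number. Compound 3 therefore stands on the weak side of the other two, with its true value unknown. Compound 4 `COc1ccc(CSc2nc3nc(C)cc(Nc4cc(-c5ccccc5)[nH]n4)n3n2)cc1` has 4-methoxyphenyl in place of ethynyl on a saturated chain carbon bound to a sulfur. Among the compounds with values here, two measured steps bear on this change, since both bring in the ethynyl group: an at least 10-fold higher number from compound 1 to compound 3 (1.00 log units; beyond the scatter) and an at least 6.1-fold higher number from compound 2 to compound 3 (0.78 log units; beyond the scatter). Run in reverse, they suggest that replacing ethynyl with an aromatic ring should lower the number by a clear margin. Compound 2, at 8110 nM, is the closest guide, as it carries 4-fluorophenyl at the same place. The expected change in this assay is an at least 7.1-fold lower number from compound 3 to compound 4 (0.85 log units; beyond the scatter), a step toward stronger inhibition. For compound 4 the estimated value is 7000 nM, with an expected range of 2500 nM to 20000 nM.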

Compound 4, half-maximal inhibitory concentration: 8110 nM
The estimate for compound 4 lay 1.2-fold (0.06 log units) below the measured number, and the stated range covers the measured number.
By their numbers in this assay, from the lowest: compounds 1, 2 and 4 (each within the scatter of the next). At a limit, above all of these: compound 3.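

Bringing in 4-methoxyphenyl on a saturated chain carbon bound to a sulfur gives, in this assay, an at least 6.1-fold lower number from compound 3 to compound 4 (0.78 log units; beyond the scatter), so the ethynyl compound now stands apart from three compounds that carry an aromatic ring at this place. New here is that swapping the ring's substituent leaves the reading within the scatter: methoxy in place of fluoro on an aromatic carbon gives no change at the digits printed from compound 2 to compound 4 (within the scatter), and 4-methoxyphenyl in place of benzyl gives a 1.6-fold higher number from compound 1 to compound 4 (0.22 log units; within the scatter). The step from compound 3 remains only a bound, because compound 3 stands at a limit: the limit of > 50000 nM in this assay, at which 1 of the 4 values shown sits.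

The compounds shown leave open whether an aromatic ring is needed at this place, or whether a longer saturated alkyl chain would read the same. They also leave open what an amine or a carboxylic acid on the ring would do.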